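A few compounds are considered here, and "the series" means these few. Any claim that something is new, unique, unknown or untested is made for them only; others in the source may bear on it.

Measured in an ADME assay on BJ cells (Homo sapiens) for cytotoxicity, with a stated time of 72 h; a higher number here means that more compound is needed for the effect, a lower number that less compound is needed:
Compound 1 `Cc1cc(NC(=O)Nc2cccc(C(N)=O)c2)c2ccccc2n1` gives > 25000 nM
Compound 2 `Cc1cc(NC(=O)Nc2ccccc2C(C)(C)C)c2ccccc2n1` gives 22000 nM

Compound 1 has no exact number in this test. Its result of > 25000 nM is a limit of the assay, not a measured number.

Compound 3 (`Cc1cc(NC(=O)Nc2cccc(C(F)(F)F)c2)c2ccccc2n1`) has yet to be tested. It keeps the core of compound 1 and changes one group, with trifluoromethyl in place of carbamoyl on an aromatic carbon, meta to a large group (trifluoromethyl in place of carbamoyl on an aromatic carbon).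

Within the data shown here, no measured pair shows what such a swap does. Among the measured compounds shown here, the only exact number available is that of compound 2, at 22000 nM, so a modest move towards less compound needed is expected in this assay. The expected change is an at least 1.3-fold lower number from compound 1 to compound 3 (0.14 log units; that floor lies within the scatter). Compound 3 could also end at the limit of the assay. For compound 3 the estimated value is 18000 nM, with an expected range from 7000 nM to 25000 nM.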

Compound 3, half-maximal effective concentration: > 25000 nM
Compound 3: only a limit was reported (the forecaster's own chance of this, stated with the estimate: 45%); middle value at least 1.3-fold (0.14 log units) from the limit.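

Among these compounds, compound 1 and compound 3 each give only a limit of the assay rather than an exact number, and no step between them can be read. The compounds shown leave open how far trifluoromethyl in place of carbamoyl shifts the amount of compound needed for the effect, or in which direction.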